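Trifluoromethyl in place of nitro in a cytotoxicity assay

A few compounds are considered here, and "the series" means these few. Any claim that something is new, unique, unknown or untested is made for them only; others in the source may bear on it.

Compound 1 `O=[N+]([O-])c1ccccc1NC(CO)CO`: in a functional assay on Caco-2 cells (Homo sapiens) for cytotoxicity (a lower number here means a stronger inhibitor, a higher number a weaker inhibitor), compound 1 gives > 100000 nM, a limit of the assay.
Compound 2 `O=[N+]([O-])c1ccc(NC(CO)CO)c([N+](=O)[O-])c1`: in this assay compound 2 gives > 100000 nM, also a limit.

Compound 2 therefore stands at the limit shared by both measured compounds, as the limit of > 100000 nM in this assay, at which 2 of the 2 values shown sit, shows. Among the compounds with values here, the only measured step, a step that the two limits leave unreadable from compound 1 to compound 2, is unreadable because both of its values are limits. Compound 3 `O=[N+]([O-])c1cc(C(F)(F)F)ccc1NC(CO)CO` differs from compound 2 by trifluoromethyl in place of nitro on an aromatic carbon. Within the data shown here, no measured step gives a readable size for this change, so no step beyond the scatter is expected: a number no higher from compound 2 to compound 3 (the limit leaves the size open). Compound 3 is estimated at 100000 nM, in the range 40000 nM to 300000 nM, most likely again reported only as a limit.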

Compound 3, half-maximal inhibitory concentration: > 100000 nM
Compound 3: no number, only a limit; the forecaster's own chance of this, stated with the estimate: 85%; the middle value sits exactly at the limit.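

In this assay compound 3 gives > 100000 nM, again a limit. Within the data shown here, no step between compound 1, compound 2 and compound 3 can be read: the limit of > 100000 nM in this assay, at which 3 of the 3 values shown sit. The compounds shown leave open whether hydrogen, nitro or trifluoromethyl on that aromatic carbon makes any difference in this assay.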